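The source may hold more compounds than are shown below. What is called first, only, known or untested is meant among the compounds shown, and "the series" means these compounds.

In a functional assay on HeLa cells (Homo sapiens) for antiproliferative activity, read by MTT assay, with a stated time of 72 h (on this read-out higher numbers stand for weaker inhibition and lower numbers for stronger inhibition), compound 1 `O=C1COc2ccc(-c3cccc(NS(=O)(=O)c4ccc(F)cc4)c3)cc2N1` reads > 40000 nM and this is a limit of the assay, not a number. Compound 1 therefore stands at the limit of > 40000 nM in this assay, at which 2 of the 3 values shown sit, and offers no exact starting value. Compound 3 `COc1cccc(N2C(=O)COc3ccc(-c4ccc(O)cc4)cc32)c1` reads > 40000 nM and this too is a limit. Compound 2 `COc1cccc(N2C(=O)COc3ccc(-c4cnc5ccccc5c4)cc32)c1` gives an actual number, 11400 nM in this assay for this core variant.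

The next step leads to compound 4 `CC(C)N1C(=O)COc2ccc(-c3cccc(NS(=O)(=O)c4ccc(F)cc4)c3)cc21` where isopropyl stands in place of hydrogen on an amide-type nitrogen in a ring isopropyl in place of hydrogen on an amide-type nitrogen in a ring and the rest of compound 1 is unchanged. Among the measured compounds shown here, no measured pair shows this change alone. Compounds 2 and 3 both carry a group on that nitrogen, but they also differ from compound 1 elsewhere, and only compound 2 gives a number, so the hint is weak.

A small move toward stronger inhibition is therefore expected, an estimated at least 1.6-fold lower number from compound 1 to compound 4 (0.20 log units; that floor lies within the scatter) and the assay may well report a limit again. For compound 4 the expected value is 25000 nM with an estimated range from 6000 nM to 80000 nM in this assay.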

Compound 4, half-maximal inhibitory concentration: 22700 nM
Beside the measured number, compound 4's estimate is 1.1-fold (0.04 log units) above it; the range from low to high includes it.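

Compound 1 reads > 40000 nM, which is a limit of the assay and not a number. Among the compounds shown here, compound 4 gives the first exact number for the core of compound 1 with a group on the amide-type nitrogen in a ring, so in this assay this position can carry isopropyl and still give a reading. For the compounds shown here, putting isopropyl in place of hydrogen gives an at least 1.7-fold lower number from compound 1 to compound 4 (0.24 log units; that floor lies within the scatter), and only this floor of the step can be stated, not its true size.

Going by these compounds, it remains open whether an ethyl group, a longer chain or a chain ending in an amine on this nitrogen would shift the number further. Compound 2 and compound 3 also carry a group there but differ from compound 4 elsewhere, so they cannot settle this.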